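The source may report more compounds than this note shows. Statements on the series, on what has been measured and on what is new or still open speak of the compounds shown alone.

For the measured compounds named here, compound 1, whose structure is `CCCC(=O)N/N=C1\C[C@H]2CC[C@]1(C)C2(C)C`, is the one member of this small set for which an ADME assay on Vero cells (Chlorocebus sabaeus) for cytotoxicity, read by spectrophotometry, with a stated time of 4 days (on this read-out lower numbers stand for higher toxicity in this test and higher numbers for lower toxicity in this test), returns a number: in it compound 1 gives 854000 nM, and it therefore stands as the only compound with a readable value. Compound 2, with the structure `CC1(C)[C@@H]2CC[C@@]1(C)/C(=N/NC(=O)C(F)(F)F)C2`, is recorded in this assay only as a limit, > 250000 nM. Compound 3, whose structure is `CC12C=CC3(O1)C(C(=O)N1CCCOC13)C2C(=O)N/N=C1\C[C@H]2CC[C@]1(C)C2(C)C`, is likewise recorded in this assay only as a limit, > 250000 nM. Going by the values given here, the single step between measured compounds that differ in one place, a step that the limit leaves unreadable from compound 1 to compound 2, is left unreadable by that limit, a point underlined by the limit of > 250000 nM in this assay, at which 2 of the 3 values shown sit.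

Compound 4 has the structure `CC1(C)[C@@H]2CC[C@@]1(C)/C(=N/NC(=O)c1ccc(Br)cc1)C2` and differs from compound 1 by 4-bromophenyl in place of propyl on a carbonyl carbon. Among the compounds with values here, no measured step that can be read bears on this change, so the size and direction of the step in this assay cannot be drawn from the measured compounds, and the account turns to the estimate. Compound 4 is expected to give 300000 nM, between 80000 nM and 1000000 nM, an estimated step of a 2.8-fold lower number from compound 1 to compound 4 (0.45 log units; beyond the scatter).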

Compound 4, half-maximal cytotoxic concentration: 288000 nM
Compound 4: the middle estimate sits 1.0-fold (0.02 log units) above what was measured; the measured number falls inside the stated range.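

For the compounds shown here, compound 4 gives the first readable step at this position: with 4-bromophenyl in place of propyl on a carbonyl carbon, this assay shows a 3.0-fold lower number from compound 1 to compound 4 (0.47 log units; beyond the scatter). Going by these compounds alone, the group on the carbonyl carbon can therefore move this read-out beyond the usual scatter, towards higher toxicity in this test, which the earlier compounds could not show. The step remains modest, even though the entering group brings an aromatic ring of six carbons where the propyl chain had no ring.

Going by these compounds, whether the ring or the bromine carries this shift stays open, and a plain phenyl, a 4-chlorophenyl or a longer chain such as hexyl on the same carbonyl carbon would separate these. The step between trifluoromethyl and 4-bromophenyl also cannot be read, and the same holds for every other step that ends on a limit, because of one shared feature: the limit of > 250000 nM in this assay, at which 2 of the 4 values shown sit.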